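Sulfamoyl in Place of Phenylethenyl on a Shared Core

The source may report more compounds than this note shows. Statements on the series, on what has been measured and on what is new or still open speak of the compounds shown alone.

Compound 1 `C=C(c1ccccc1)c1ccc2c(c1)[C@@H](/N=C(\NC#N)Nc1ccc(Cl)cc1)[C@H](O)C(C)(C)O2` gives 10700 nM in a functional assay (aorta) with Rattus norvegicus as the target (a lower number here means a stronger inhibitor, a higher number a weaker inhibitor), the higher of the two numbers measured, while compound 2 `CC1(C)Oc2ccc(S(=O)(=O)c3ccccc3)cc2[C@@H](/N=C(\NC#N)Nc2ccc(Cl)cc2)[C@@H]1O` gives 500 nM in this assay. Compound 3 `CC1(C)Oc2ccc(C(=O)Nc3ccccc3)cc2[C@@H](/N=C(\NC#N)Nc2ccc(Cl)cc2)[C@@H]1O` reaches only a limit of this assay, > 100000 nM. The step of a 21-fold lower number from compound 1 to compound 2 (1.33 log units; beyond the scatter) was large, whereas an at least 9.3-fold higher number from compound 1 to compound 3 (0.97 log units; beyond the scatter) ran the other way, and an at least 200-fold higher number from compound 2 to compound 3 (2.30 log units; beyond the scatter) was large. Compound 4 `CC1(C)Oc2ccc(S(N)(=O)=O)cc2[C@@H](/N=C(\NC#N)Nc2ccc(Cl)cc2)[C@@H]1O` differs from compound 1 by sulfamoyl in place of 1-phenylethenyl on an aromatic carbon. The sulfamoyl keeps the sulfonyl found in the phenylsulfonyl of compound 2 but lacks its ring, so the change is expected to follow the direction of a 21-fold lower number from compound 1 to compound 2 (1.33 log units; beyond the scatter) at a smaller size, namely a 3.6-fold lower number from compound 1 to compound 4 (0.55 log units; beyond the scatter). Compound 4 is therefore estimated at 3000 nM, within 800 nM to 12000 nM.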

Compound 4, half-maximal inhibitory concentration: 41300 nM
The estimate for compound 4 lay 14-fold (1.14 log units) below the measured number, and the stated range ends below it.
By their numbers in this assay, from the lowest: compound 2; then compound 1; then compound 4. At a limit, above all of these: compound 3.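

In this assay the sulfonyl alone does not hold the gain of compound 2 at this aromatic carbon: amino in place of phenyl on the sulfonyl sulfur costs most of it (an 83-fold higher number from compound 2 to compound 4 (1.92 log units; beyond the scatter)). Sulfamoyl in place of 1-phenylethenyl also lands on the higher side (a 3.9-fold higher number from compound 1 to compound 4 (0.59 log units; beyond the scatter)), and what counts here is the phenyl on the sulfonyl, not the sulfonyl by itself. Sulfamoyl still gives a lower number than phenylcarbamoyl (an at least 2.4-fold lower number from compound 3 to compound 4 (0.38 log units; beyond the scatter)), a step that rests on a limit: (the limit of > 100000 nM in this assay, at which 1 of the 4 values shown sits).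

As far as these compounds go, whether a methyl, a benzyl or a dimethylamino on the sulfonyl sulfur would recover the number of compound 2 stays open. So does whether a chlorophenyl there would go lower still.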